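Moving the ring attachment point on the hydroxymethyl side chain

The compounds below may be only part of what the source reports. "The series", "measured", "known", "first", "only" and "open" are said of these compounds alone.

The study concerns a shared core carrying a chloro-substituted aromatic ring, with a side chain that bears a hydroxymethyl group and a small oxygen-containing saturated ring. Compound 1, `Cc1cc(C)c(CN2CCc3c(Cl)cc([C@H](CO)[C@H]4CCOC4)c(Cl)c3C2=O)c(=O)[nH]1`, is the reference point. Among the measured compounds shown here, in an ADME assay on microsomes from liver (Homo sapiens) for metabolic stability, read by LC-MS, using NADPH, with stated times of 10 min and 45 min, tested at 1 uM (on this read-out lower numbers stand for slow clearance and higher numbers for fast clearance), compound 1 gives 21.3 uL/min, the only single number in this set. Compound 2, `COC(c1cc(Cl)c2c(c1Cl)C(=O)N(Cc1c(C)cc(C)[nH]c1=O)CC2)C1CCOCC1`, differs from compound 1 in several places. In this assay compound 2 gives 130 uL/min; 129 uL/min (2 entries), a reading that sits well above that of compound 1, as the repeated entries show in the several entries of compound 2 in this assay, 130 uL/min; 129 uL/min (2 entries).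

Compound 3, `Cc1cc(C)c(CN2CCc3c(Cl)cc([C@@H](CO)[C@@H]4CCCO4)c(Cl)c3C2=O)c(=O)[nH]1`, is the unmeasured partner of compound 1. The difference between them is a group of 8 heavy atoms (6 carbon, 2 oxygen; one five-membered non-aromatic ring with 1 hetero atom) in place of a group of 8 heavy atoms (6 carbon, 2 oxygen; one five-membered non-aromatic ring with 1 hetero atom), on an aromatic carbon. The two have the same atoms, joined differently: the five-membered ring with one hetero atom is attached through a different ring carbon, and both stereocentres are redrawn.

For the measured compounds named here, with no measured step of this kind to lean on, the change is expected to lie within the usual scatter: the step of a 1.3-fold higher number from compound 1 to compound 3 (0.10 log units; within the scatter) is estimated to be small and without a clear direction. Compound 3 is therefore expected to show roughly 27 uL/min, with a plausible range from 12 uL/min to 65 uL/min.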

Compound 3, intrinsic clearance in a liver preparation (reported as CLH), per the amount of preparation that the assay uses: 70.3 uL/min
Estimate against measurement, compound 3: 2.6-fold (0.42 log units) below; measured number above the stated range.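

Within the shared core, the side chain on the aromatic carbon ortho to a chloro group proves sensitive in this assay to how it is joined: with the same atoms and the same five-membered non-aromatic ring with 1 hetero atom, redrawing the ring attachment and both stereocentres gives a 3.3-fold higher number from compound 1 to compound 3 (0.52 log units; beyond the scatter). Among the compounds shown here, the earlier compounds offered no single-place step at this position, so this is the first sign that a rearrangement alone, with the counts of hydrogen-bond donors and acceptors unchanged, can move the read-out beyond the usual scatter, although the step is modest. One compound gives a view of how closely repeated readings agree in this assay: the several entries of compound 2 in this assay, 130 uL/min; 129 uL/min (2 entries).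

The attachment point and the two stereocentres change together between compound 1 and compound 3, so the compounds shown do not separate their contributions, and a stereoisomer of compound 1 with the ring attachment kept would be needed to do that. They also leave open how this position would read with an amine or a carboxylic acid in place of the hydroxymethyl group.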